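This account rests on a few compounds, and the source may have more. Where it says the series, first, only, none or still open, it means among the compounds named here.

Measured compounds, all in a functional assay on DU-145 cells (Homo sapiens) for cytotoxicity, read by sulforhodamine B assay, with a stated time of 48 h; on this read-out higher numbers stand for weaker inhibition of growth and lower numbers for stronger inhibition of growth:
- compound 1 `CN1CCN(c2nc(Nc3ccc(C#N)c(C(F)(F)F)c3)nc(Oc3ccnc4ccccc34)n2)CC1`: > 100000 nM, a limit of the assay
- compound 2 `N#Cc1ccc(Nc2nc(Oc3ccnc4ccccc34)nc(N3CCN(c4ccccc4)CC3)n2)cc1C(F)(F)F`: > 100000 nM, likewise a limit of the assay

Compound 2 stands at the assay limit on the single read-out available; it shares that position with compound 1, and both values sit at the limit of > 100000 nM in this assay, at which 2 of the 2 values shown sit. Among the measured compounds shown here, the one measured step, a step that the two limits leave unreadable from compound 1 to compound 2, carries phenyl onto the ring amine nitrogen in place of methyl, but with both ends at the limit its size cannot be read, so no direction of change within the pair is established.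

Compound 3 `N#Cc1ccc(Nc2nc(Oc3ccnc4ccccc34)nc(N3CCN(c4cccc(Cl)c4Cl)CC3)n2)cc1C(F)(F)F` is the next member. Its change from compound 2 is 2,3-dichlorophenyl in place of phenyl on an amine nitrogen in a ring. For the measured compounds named here, the only step that touches the same position is the unreadable one from compound 1 to compound 2; it gives no measured size to carry forward, and neither compound offers a numeric value to anchor a change. Going by the values given here, the expectation in this assay is therefore no step readable beyond the scatter, with the result for compound 3 most likely reported again as a limit, meaning an expected step that the limit leaves unreadable from compound 2 to compound 3. Compound 3 is estimated at 150000 nM, with a range from 50000 nM to 500000 nM.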

Compound 3, concentration for total growth inhibition: > 100000 nM
Compound 3 was reported as a limit; the forecaster's own chance of this, stated with the estimate: 80%; the middle value does not contradict the limit.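

No step can be read among compound 1, compound 2 and compound 3, as all three values are limits of the assay and none gives a size: the limit of > 100000 nM in this assay, at which 3 of the 3 values shown sit.

The compounds shown leave open how methyl, phenyl and 2,3-dichlorophenyl on the amine nitrogen in the ring rank against one another, and whether any member of this series gives a value inside the readable range.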